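The compounds below may be only part of what the source reports. "The series", "measured", "known", "first", "only" and "open" are said of these compounds alone.

Measured so far:

- compound 1 `CCCCCCCC/C=C\CCCCCCCC(=O)N1CCCCC1`: 7.7 ug/mL
- compound 2 `CCCCCCCCCCCCCCCCCC(=O)N1CCCC1`: 6.3 ug/mL
- compound 3 `CCCCCCCCCCCCCCCC(=O)N1CCOCC1`: 28.9 ug/mL

All three were tested in an ADME assay on HaCaT cells (Homo sapiens) for cytotoxicity, read by sulforhodamine B assay, with a stated time of 48 h; a lower number here means that less compound is tolerated, a higher number that more compound is tolerated. Among them, compound 2 gives the lowest number, 6.3 ug/mL, but it sits within the scatter of compound 1, so no order between these two can be read; compound 3, at 28.9 ug/mL, lies clearly beyond that scatter, so more of compound 3 is tolerated than of compound 2.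

Compound 4 `CCCCCCCCCCCCCCCCCC(=O)N[C@@H](C)c1ccccc1` has not been measured. It differs from compound 2 in one place: (1-phenylethyl)amino in place of pyrrolidin-1-yl on a carbonyl carbon. For the measured compounds named here, no measured pair shows a change of this kind, so the expectation rests on the spread of the three values alone. A modest rise is expected for compound 4, with the step of a 1.6-fold higher number from compound 2 to compound 4 (0.20 log units; within the scatter) likely staying within the scatter or only slightly beyond it. Compound 4 is thus estimated at 10 ug/mL, between 4 ug/mL and 25 ug/mL.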

Compound 4, concentration lethal to 50% of the cells: 69.5 ug/mL
For compound 4 the middle estimate is 7.0-fold (0.84 log units) below the measured one; the measured number lies above the stated range.
By their numbers in this assay, from the lowest: compounds 2 and 1 (each within the scatter of the next); then compound 3; then compound 4.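

In this assay, the change of group on a carbonyl carbon gives an 11-fold higher number from compound 2 to compound 4 (1.04 log units; beyond the scatter). This shows that the group at this place can make a large difference to how much compound the cells tolerate. Nothing available explains the step.

On these data alone, the change brings in an aromatic ring, an amide hydrogen and a defined stereocentre all at once, so their separate shares remain unknown. Open questions include how a plain benzylamino group or the mirror-image (1-phenylethyl)amino group would compare.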